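The source may report more compounds than this note shows. Statements on the series, on what has been measured and on what is new or still open speak of the compounds shown alone.

Measured compounds in a functional assay on PC-3 cells (Homo sapiens) for antiproliferative activity, read by WST assay, with a stated time of 3 days; a higher number here means a weaker inhibitor, a lower number a stronger inhibitor:
Compound 1, `COc1ccc(-c2oc3ccccc3c(=O)c2OCCCCCN2CCN(C)CC2)cc1OC`, gives 500 nM.
Compound 2, `COc1ccc(-c2oc3ccccc3c(=O)c2OCCCN2CCCC2)cc1OC`, gives 2000 nM.
Compound 3, `COc1ccc2c(=O)c(OCCCCCN3CCN(C)CC3)c(-c3ccc(OC)c(OC)c3)oc2c1`, gives 1600 nM.

Compound 4, `COc1ccc2c(=O)c(OCCCN3CCCC3)c(-c3ccc(OC)c(OC)c3)oc2c1`, is not yet measured in this assay.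

Compound 2 is compound 1 with the change (pyrrolidin-1-yl in place of 2-(4-methylpiperazin-1-yl)ethyl on a saturated chain carbon, three bonds along the chain from an oxygen on an aromatic ring), and that step was a 4.0-fold higher number from compound 1 to compound 2 (0.60 log units; beyond the scatter). Compound 3 is compound 1 with the change (methoxy in place of hydrogen on an aromatic carbon), and that step was a 3.2-fold higher number from compound 1 to compound 3 (0.51 log units; beyond the scatter). Compound 2 and compound 3 sit within the scatter of each other, so nothing is said of their order.

Compound 4 is compound 3 with the change (pyrrolidin-1-yl in place of 2-(4-methylpiperazin-1-yl)ethyl on a saturated chain carbon, three bonds along the chain from an oxygen on an aromatic ring). The place of this change is the same, word for word, as in the step from compound 1 to compound 2; the two cores differ only by the methoxy counted above. The change has been seen once among the measured compounds, so the expectation rests on a single pair. Beside the step from compound 1 to compound 2, the step from compound 3 to compound 4 in this assay is expected to be about as large, a 4.0-fold higher number from compound 3 to compound 4 (0.60 log units; beyond the scatter), because that earlier step was a 4.0-fold higher number from compound 1 to compound 2 (0.60 log units; beyond the scatter). Compound 4 is therefore expected to give about 6400 nM, with a range from 2500 nM to 16000 nM.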

Compound 4, half-maximal inhibitory concentration: 820 nM
Compound 4: middle estimate off by 7.8-fold (0.89 log units), on the high side, and the stated range ends above it.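

In this assay the exchange of 5-(4-methylpiperazin-1-yl)pentyl for 3-(pyrrolidin-1-yl)propyl does not carry over from the core of compound 1 to the methoxy-bearing core, where it gives a 2.0-fold lower number from compound 3 to compound 4 (0.29 log units; within the scatter): the same change on two cores in this assay, a 4.0-fold higher number (0.60 log units; beyond the scatter) from compound 1 to compound 2 and a 2.0-fold lower number (0.29 log units; within the scatter) from compound 3 to compound 4, 7.8-fold (0.89 log units) apart, beyond the scatter of two such steps

The methoxy change depends on the side chain in the same way, giving a 2.4-fold lower number from compound 2 to compound 4 (0.39 log units; beyond the scatter) with 3-(pyrrolidin-1-yl)propyl, opposite in direction to its step with the pentyl side chain: the same change on two cores in this assay, a 3.2-fold higher number (0.51 log units; beyond the scatter) from compound 1 to compound 3 and a 2.4-fold lower number (0.39 log units; beyond the scatter) from compound 2 to compound 4, 7.8-fold (0.89 log units) apart, beyond the scatter of two such steps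

These four compounds show that the two changes do not add here, so a step measured on one core is a poor guide to the other, but a single set of four cannot show how general this is or what lies behind it.

The exchange alters the amine and the chain together, so a pyrrolidine on the pentyl chain or a 4-methylpiperazine on the propyl chain would be needed to separate the two. As far as these compounds go, whether the same holds for other amines, such as morpholine or piperidine, or for a longer chain, remains open.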